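The compounds below may be only part of what the source reports. "The series", "measured", "known", "first", "only" and "open" are said of these compounds alone.

Compound 1 `COc1c(OCc2nc3ccccc3[nH]2)cc(O)c2c(=O)cc(-c3ccccc3)oc12`: > 100000 nM
Compound 2 `CCCCNCCCCOc1c(O)cc(O)c2c(=O)cc(-c3ccccc3)oc12`: "not determined" (no result reported)
Compound 3 `COc1c(OCc2ncc(C)o2)cc(O)c2c(=O)cc(-c3ccccc3)oc12`: > 100000 nM

In a functional assay on A549 cells (Homo sapiens) for cytotoxicity, read by MTT assay, with a stated time of 48 h (a lower number here means a stronger inhibitor, a higher number a weaker inhibitor), compound 1 reaches only a limit of the assay, > 100000 nM. Compound 3 likewise gives only a limit, > 100000 nM. Compound 1 and compound 3 both sit at the limit of > 100000 nM in this assay, at which 2 of the 3 values shown sit. For the measured compounds named here, the one step between measured compounds, a step that the two limits leave unreadable from compound 1 to compound 3, therefore cannot be read. Compound 2 has no result in this assay and no number it can be placed against. Compound 4 `O=c1cc(-c2ccccc2)oc2c(OCCCN3CCCC3)c(O)cc(O)c12` differs from compound 2 by pyrrolidin-1-yl in place of (butylamino)methyl on a saturated chain carbon, three bonds along the chain from an oxygen on an aromatic ring. Going by the values given here, no measured step bears on this change: compound 1 and compound 3 carry no such chain, and compound 2 is unmeasured, so neither a direction nor a size can be expected for the step in this assay. Compound 4 is expected at 50000 nM, with a range of 8000 nM to 200000 nM, and may well give only a limit.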

Compound 4, half-maximal inhibitory concentration: > 100000 nM
Compound 4 gave a limit, no number; the forecaster's own chance of this, stated with the estimate: 50%; at least 2.0-fold (0.30 log units) between middle value and limit.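

Compound 4 gives only a limit, > 100000 nM, and compound 2 has no result, so no new step can be read from compound 2 to compound 4. The compounds shown leave open which group on the shared core, if any, would give a number in this assay.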